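The compounds below may be only part of what the source reports. "The series", "measured", "known", "first", "only" and "open" are said of these compounds alone.

Measured so far:
Compound 1 `O=C1NC(=O)c2c1c1c3ccc(CN4CCNCC4)cc3[nH]c1c1c2c2cccc3c2n1CCC3`: > 10000 nM (a limit)
Compound 2 `O=C1NC(=O)c2c1c1c3ccc(CN4CCCNCC4)cc3[nH]c1c1c2c2cccc3c2n1CCC3`: 7600 nM

Within the data shown here, in a functional assay on HCT-116 cells (Homo sapiens) for cytotoxicity (on this read-out higher numbers stand for weaker inhibition and lower numbers for stronger inhibition), compound 2 gives 7600 nM, the only actual number so far. Compound 1 gives > 10000 nM, which is a limit of the assay and not a number.

The next compound is compound 3 `O=C1NC(=O)c2c1c1c3ccc(C(F)(F)F)cc3[nH]c1c1c2c2cccc3c2n1CCC3`, which carries trifluoromethyl in place of (1,4-diazepan-1-yl)methyl on an aromatic carbon. Among the measured compounds shown here, only one measured step offers any guidance: an at least 1.3-fold lower number from compound 1 to compound 2 (0.11 log units; that floor lies within the scatter). It lies within the scatter, but it exchanged only the ring of the side chain, whereas here the whole side chain leaves, so it bears on this change only weakly. No step beyond the scatter can therefore be expected in this assay, in either direction. The expected step is a 1.3-fold lower number from compound 2 to compound 3 (0.10 log units; within the scatter). For compound 3 the estimated value is 6000 nM, with an expected range from 1500 nM to 20000 nM.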

Compound 3, half-maximal inhibitory concentration: 1480 nM
Compound 3: middle estimate off by 4.1-fold (0.61 log units), on the high side, and the stated range ends above it.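

The earlier compounds shown here changed only the ring of the side chain, and that step stayed within the scatter, whereas replacing the whole side chain on this aromatic carbon with trifluoromethyl has a clear effect in this assay: a 5.1-fold lower number from compound 2 to compound 3 (0.71 log units; beyond the scatter). The second comparison points the same way, so neither ring-bearing side chain is needed for cytotoxicity in these cells: an at least 6.7-fold lower number from compound 1 to compound 3 (0.82 log units; beyond the scatter). Compound 1 gives a limit and not a number, so that second step is only a floor: the limit of > 10000 nM in this assay, at which 1 of the 3 values shown sits.

From the compounds shown here alone, what stays open is whether the stronger inhibition comes from losing the ring side chain or from the trifluoromethyl group itself. A comparison with a simple methyl, a chlorine atom or a nitrile on this same aromatic carbon could separate the two.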